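The source may report more compounds than this note shows. Statements on the series, on what has been measured and on what is new or still open speak of the compounds shown alone.

Going by the values given here, in an ADME assay on microsomes (Homo sapiens) for metabolic stability (on this read-out higher numbers stand for fast clearance and lower numbers for slow clearance), two related compounds have numbers so far. Compound 1 (`CCc1cc(C(F)(F)F)c2cccc(OCc3c(Cl)ccc(S(=O)(=O)N4CCC[C@H]4C(=O)NC)c3Cl)c2n1`) gives 300 mL/min/kg, and compound 2 (`COC[C@@H]1CCCN1S(=O)(=O)c1ccc(Cl)c(COc2cccc3c(C(F)(F)F)cc(C)nc23)c1Cl`) gives 450 mL/min/kg. Among the compounds with values here, these two values lie within the usual scatter of each other, so compound 2 cannot be told apart from its only measured neighbour on this read-out.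

Compound 3 (`Cc1cc(C(F)(F)F)c2cccc(OCc3c(Cl)ccc(S(=O)(=O)N4CCC(C#N)CC4)c3Cl)c2n1`) awaits measurement. It differs from compound 2 in one place, on a sulfonyl sulfur: 4-cyanopiperidin-1-yl in place of 2-(methoxymethyl)pyrrolidin-1-yl on a sulfonyl sulfur. No measured pair of compounds differs in only one place, so the size of this change has not been shown directly. The nearest guide is compound 1 at 300 mL/min/kg, which also carries a different group on a sulfonyl sulfur, although it differs elsewhere as well. With so little evidence, only a small move towards slower clearance is expected, and it should not exceed the scatter. The expected step, a 1.5-fold lower number from compound 2 to compound 3 (0.18 log units; within the scatter), is correspondingly modest. For compound 3 the estimated clearance is 300 mL/min/kg, with an expected range from 130 mL/min/kg to 600 mL/min/kg.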

Compound 3, clearance: 433 mL/min/kg
Estimate against measurement, compound 3: 1.4-fold (0.16 log units) below, within the range that was stated.
By their numbers in this assay, from the lowest: compounds 1, 3 and 2 (each within the scatter of the next).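

At the sulfonyl sulfur, this assay now offers its first direct reading of a single change: 4-cyanopiperidin-1-yl in place of 2-(methoxymethyl)pyrrolidin-1-yl gives a 1.0-fold lower number from compound 2 to compound 3 (0.02 log units; within the scatter) and leaves the two compounds indistinguishable on this read-out. The exchange alters the ring size from five-membered to six-membered, brings in a nitrile, and removes the ether oxygen and the defined stereocentre. The two compounds of this one pair nevertheless lie within the scatter of each other. From the compounds shown here alone, nothing measured accounts for this outcome, and whether the two groups resemble each other in any particular respect remains unknown.

A single pair cannot show whether this position is generally insensitive to substitution, and a group such as a morpholine, a dimethylamino group or a piperidine bearing a carboxylic acid could still give a step beyond the scatter. Compound 1 differs from compound 3 in more than one place, so the part played by its methylamide-bearing pyrrolidine and by its ethyl group on the shared core also remains unresolved.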